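Hydroxyethyl amide substitution in the pyrrole-fused piperidine series

The compounds below may be only part of what the source reports. "The series", "measured", "known", "first", "only" and "open" are said of these compounds alone.

Among the measured compounds shown here, compound 1 `Cn1ncc(Cl)c1-c1cc(C(=O)N[C@@H]2CN[C@H](CC(N)=O)C[C@H]2c2ccc(Cl)c(Cl)c2)oc1Cl` is the only compound of this series with a result in a functional assay on LNCaP cells (Homo sapiens) for antiproliferative activity; a lower number here means a stronger inhibitor, a higher number a weaker inhibitor: there compound 1 gives 160 nM. Compound 2 `CC(=O)OCC[C@@H]1C[C@@H](c2ccc(F)c(F)c2)[C@H](NC(=O)c2cc(-c3c(Cl)cnn3C)c(Cl)o2)CN1` carries a different halogen pattern on the pendant aryl ring and a different side chain; in this assay compound 2 reads "not determined" (no result reported). Compound 3 `Cn1ncc(Cl)c1-c1cc(C(=O)N[C@@H]2CN[C@H](CC(=O)NCCO)C[C@H]2c2ccc(Cl)c(Cl)c2)oc1Cl` differs from compound 1 by 2-hydroxyethyl in place of hydrogen on an amide-type nitrogen. For the measured compounds named here, no measured pair shows this change, so the size of the step is open. The expectation is a step within the usual scatter, a 1.4-fold higher number from compound 1 to compound 3 (0.14 log units; within the scatter), with a slight lean toward weaker inhibition. Compound 3 is therefore estimated at 220 nM, within 80 nM to 600 nM.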

Compound 3, half-maximal inhibitory concentration: 40 nM
Beside the measured number, compound 3's estimate is 5.5-fold (0.74 log units) above it; measured number outside the range, below it.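

Substitution on the amide-type nitrogen of the carbamoylmethyl side chain is tolerated in this assay: 2-hydroxyethyl in place of hydrogen gives a 4.0-fold lower number from compound 1 to compound 3 (0.60 log units; beyond the scatter), so activity at this position does not depend on the unsubstituted amide. This is one modest step, and compound 2 adds no number on another halogen pattern. Nothing available explains the gain.

On these data alone, how a plain ethyl group, a 3-hydroxypropyl chain, or a terminal amine or carboxylic acid on this nitrogen would read remains open. As far as these compounds go, whether the step carries over to the halogen pattern of compound 2 is also open.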